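Swapping a cyclobutyl for a propynyl on an adenosine analogue

The source may hold more compounds than are shown below. What is called first, only, known or untested is meant among the compounds shown, and "the series" means these compounds.

Three compounds share one adenosine-derived core carrying an amino acid side chain on a tertiary amine. Compound 1 `CCCN(CC[C@H](N)C(=O)O)C[C@H]1O[C@@H](n2cnc3c(N)ncnc32)[C@H](O)[C@@H]1O` bears a propyl group on that amine; in an assay for inhibition of tRNA (cytosine(38)-C(5))-methyltransferase (Homo sapiens), with a stated time of 5 min, tested at 100 uM (on this read-out lower numbers stand for less inhibition and higher numbers for more inhibition at the one concentration tested (going by the name of the read-out)), compound 1 gives no result reported, so no number was obtained for it. Compound 2 `Nc1ncnc2c1ncn2[C@@H]1O[C@H](CN(CC[C@H](N)C(=O)O)CC2CCC2)[C@@H](O)[C@H]1O` carries a cyclobutylmethyl group instead, and in this assay compound 2 gives 32%. For the measured compounds named here, since this is the only number in hand, compound 2 stands alone: there is nothing to rank it against, and no step between measured compounds can be stated.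

Compound 3 `CC#CCN(CC[C@H](N)C(=O)O)C[C@H]1O[C@@H](n2cnc3c(N)ncnc32)[C@H](O)[C@@H]1O` is the next member of the set. It differs from compound 2 in a single place: prop-1-yn-1-yl in place of cyclobutyl on a saturated chain carbon bound to an amine nitrogen. The cyclobutyl leaves and a prop-1-yn-1-yl enters, so the substituent on the amine becomes but-2-yn-1-yl rather than cyclobutylmethyl.

Going by the values given here, with only one measured value, the expected step from compound 2 to compound 3, a number 4 percentage points lower from compound 2 to compound 3 (within the scatter), is estimated to stay within the usual scatter, in no clear direction. In this assay compound 3 is therefore expected to give about 28%, with a range from 5% to 55%.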

Compound 3, a percentage reported as inhibition, at one concentration (the size of the read-out at that concentration, not a potency): 61.3%
Compound 3: the middle estimate sits 33.3 percentage points below what was measured, outside the stated range (above it).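

In this assay, for the compounds shown here, replacing cyclobutyl with prop-1-yn-1-yl on a saturated chain carbon bound to an amine nitrogen gives a number 29.3 percentage points higher from compound 2 to compound 3 (beyond the scatter), the first comparison that can be read at this place, and it shows that the read-out responds to the group carried there. The substituent on the amine does not need a ring to give this level of inhibition at the one concentration tested, since but-2-yn-1-yl, with no ring and one triple bond, stands higher than cyclobutylmethyl. No measurement in hand bears on why these two groups differ.

Compound 1 has no number, so the steps involving it cannot be read, and with the propyl group unplaced, the compounds shown cannot separate the effect of gaining the triple bond from that of losing the four-membered ring. On these data alone, it also remains open how a longer chain ending in a triple bond, a phenyl ring or a chain bearing an amine would read at this place, and whether the difference between compound 2 and compound 3 would hold across a range of concentrations.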